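Adding a chloro group to compound 3

The compounds below may be only part of what the source reports. "The series", "measured", "known", "first", "only" and "open" are said of these compounds alone.

In a toxicity assay on NIH3T3 cells (Mus musculus) for cytotoxicity, read by resazurin assay (on this read-out lower numbers stand for an effect already at smaller amounts and higher numbers for an effect only at larger amounts of compound), compound 3 `c1ccc(Cn2cncc2CNc2cccc(-c3ccccc3)c2)cc1` has only a limit, > 750 nM, and not a number. This is the sole case of its kind among the compounds measured here, as the limit of > 750 nM in this assay, at which 1 of the 3 values shown sits, records. Compound 4 `Clc1ccc(Cn2cncc2CNc2cccc(-c3ccccc3)c2)cc1` differs from compound 3 by chloro in place of hydrogen on an aromatic carbon, so that benzyl becomes 4-chlorobenzyl. Among the compounds with values here, the one measured step at this place is a step that the limit leaves unreadable from compound 2 to compound 3, which gives no usable size. The nearest guidance therefore comes from two measured neighbours. Compound 1 `COC(=O)c1ccc(NCc2cncn2Cc2ccc(Cl)cc2)cc1-c1ccccc1` also carries 4-chlorobenzyl, although its core differs elsewhere, and gives 25000 nM. Compound 2 `O=[N+]([O-])c1ccc(Cn2cncc2CNc2cccc(-c3ccccc3)c2)cc1` has nitro at the same place on the same core and gives 10000 nM. Compound 4 is expected to fall close to these two values, and the direction from the limit of compound 3 cannot be firmly read. The expected step is a step that the limit leaves unreadable from compound 3 to compound 4. For compound 4, the estimated value is 12000 nM, with an expected range of 3000 nM to 40000 nM.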

Compound 4, half-maximal effective concentration: 10000 nM
Compound 4: middle estimate off by 1.2-fold (0.08 log units), on the high side, and the stated range covers the measured number.
By their numbers in this assay, from the lowest: compounds 2 and 4 (each within the scatter of the next); then compound 1.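

In this assay, chloro in place of nitro at this place gives no change at the digits printed from compound 2 to compound 4 (within the scatter), so on this shared core these two groups cannot be told apart by this read-out. With 4-chlorobenzyl held the same, hydrogen in place of methoxycarbonyl gives a 2.5-fold lower number from compound 1 to compound 4 (0.40 log units; beyond the scatter), which shows that a change elsewhere on the molecule can shift the number modestly while this swap of chloro for nitro leaves it unmoved. The step from hydrogen to chloro cannot be read, because compound 3 has only a limit: the limit of > 750 nM in this assay, at which 1 of the 4 values shown sits.

From the compounds shown here alone, whether either chloro or nitro differs from plain hydrogen at this place therefore stays open. How an amine or a carboxylic acid at this place would read in this assay also remains unknown from the compounds shown.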